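The source may hold more compounds than are shown below. What is called first, only, known or untested is meant among the compounds shown, and "the series" means these compounds.

Working notes on the series in an ADME assay (liver) for metabolic stability, with Liver microsome (Homo sapiens) as the target, read by LC-MS, using microsomes, with a stated time of 1 h, tested at 5 uM; a higher number here means that more of the compound is left, a lower number that less of the compound is left: compound 1 `Cc1nc(-c2ccccc2)c(C(=O)N2CCN(c3cccc(Cl)c3)CC2)o1` gives 13.5%, and compound 2 `Cc1cc(C)cc(N2CCN(C(=O)c3oc(C)nc3-c3ccccc3)CC2)c1` gives 25.6%, the higher of the two numbers so far. Compound 3 `COc1cc(OC)cc(N2CCN(C(=O)c3oc(C)nc3-c3ccccc3)CC2)c1` keeps the shared core and carries 3,5-dimethoxyphenyl in place of 3,5-dimethylphenyl on an amine nitrogen in a ring. Within the data shown here, only one measured step bears on this change. It sits at the same place but swaps a different group, and it is modest: a number 12.1 percentage points higher from compound 1 to compound 2 (beyond the scatter). That step gives a rough size and no direction for the new change. A step no larger than that one is therefore expected in this assay, most likely none beyond the scatter, with a slight lean downward as a judgement only. The estimated step is a number 3.6 percentage points lower from compound 2 to compound 3 (within the scatter). For compound 3 the expected value is 22%, with an estimated range from 10% to 36%.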

Compound 3, percent of the compound remaining: 15.8%
The estimate for compound 3 lay 6.2 percentage points above the measured number; measured number inside the range.
By their numbers in this assay, from the lowest: compounds 1, 3 and 2 (each within the scatter of the next, the first and the last beyond it).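

In this assay, 3,5-dimethoxyphenyl in place of 3,5-dimethylphenyl gives a number 9.8 percentage points lower from compound 2 to compound 3 (within the scatter), so this change on the amine nitrogen in a ring cannot be read as an effect. In place of 3-chlorophenyl, the same group gives a number 2.3 percentage points higher from compound 1 to compound 3 (within the scatter), so compound 3 cannot be told apart from either compound 1 or compound 2, even though those two lie beyond the scatter of each other. No measured information on the cause of these numbers is available.

Going by these compounds, whether a pyridyl ring or 3,5-difluorophenyl at this place would give a step beyond the scatter remains open. On these data alone, it is also open whether changes elsewhere on the shared core would shift the number more than changes at this position.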